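The source may report more compounds than this note shows. Statements on the series, on what has been measured and on what is new or still open speak of the compounds shown alone.

Compound 1, `N#CC1=C(N)Oc2c(c3nc4ccccc4nc3c3ccccc23)C12C(=O)N(Cc1cnnn1-c1ccccc1Br)c1ccccc12`, gives in an ADME assay on L02 cells (Homo sapiens) for antiproliferative activity, read by MTT assay, with a stated time of 48 h (a higher number here means a weaker inhibitor, a lower number a stronger inhibitor), only a limit of the assay, > 50000 nM.
Compound 2, `COc1ccc(-n2nncc2CN2C(=O)C3(C(C#N)=C(N)Oc4c3c3nc5ccccc5nc3c3ccccc43)c3ccccc32)cc1`, gives in this assay likewise only a limit, > 50000 nM.
Compound 3, `CCOc1ccccc1-n1nncc1CN1C(=O)C2(C(C#N)=C(N)Oc3c2c2nc4ccccc4nc2c2ccccc32)c2ccccc21`, gives in this assay again only a limit, > 50000 nM.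

All three measured values sit at the same assay limit, (the limit of > 50000 nM in this assay, at which 3 of the 3 values shown sit), so compound 2 stands exactly where compounds 1 and 3 stand: no number is known for it, only that it lies beyond the limit. For the same reason none of the measured steps can be read in size: a step that the two limits leave unreadable from compound 1 to compound 2, a step that the two limits leave unreadable from compound 1 to compound 3 and a step that the two limits leave unreadable from compound 2 to compound 3 all run from one limit to another.

Compound 4, `Cc1ccc(C)c(-n2nncc2CN2C(=O)C3(C(C#N)=C(N)Oc4c3c3nc5ccccc5nc3c3ccccc43)c3ccccc32)c1`, differs from compound 2 in one place: 2,5-dimethylphenyl in place of 4-methoxyphenyl on an aromatic nitrogen. The three measured steps bear on this change only in kind, since each of them also exchanges the group on the aromatic nitrogen or a substituent on that phenyl, and each left its compound at the limit; how large they were cannot be said. The account therefore expects no step beyond the scatter, a step that the limit leaves unreadable from compound 2 to compound 4, and expects compound 4 to return a limit as well. The estimate for compound 4 is 70000 nM, within a range from 30000 nM to 200000 nM.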

Compound 4, half-maximal inhibitory concentration: > 50000 nM
Compound 4: a limit, no number (the forecaster's own chance of this, stated with the estimate: 85%); the middle value is on the limit's open side.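

Compound 4 ends where compounds 1, 2 and 3 already stand, so its steps to those three compounds all run from one limit to another and none can be read in size: the limit of > 50000 nM in this assay, at which 4 of the 4 values shown sit.

The compounds shown leave open how far beyond the limit each of the four lies in this assay, and whether their differing groups on the aromatic nitrogen change anything there at all.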